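The compounds below may be only part of what the source reports. "The series", "measured", "known", "first", "only" and "open" are said of these compounds alone.

Measured compounds:
- Compound 1, `COc1ccc(/C(=C(/CCN=[N+]=[N-])c2ccccc2)c2ccccc2)cc1`, in a functional assay on MCF7 cells (Homo sapiens) for cytotoxicity, read by MTT assay, with a stated time of 72 h (on this read-out lower numbers stand for stronger inhibition and higher numbers for weaker inhibition), compound 1 is recorded as "not active" (no number reported).
- Compound 2, `COc1ccc(/C(=C(/CCN)c2ccccc2)c2ccccc2)cc1`, in this assay compound 2 gives 16900 nM.
- Compound 3, `CCN(CC)C(=O)NCC/C(=C(\c1ccccc1)c1ccc(OC)cc1)c1ccccc1`, in this assay compound 3 gives only a limit of the assay, > 50000 nM.

Compound 3 therefore stands at the weak end of what has been measured: its result is not a number but a limit, and it shares this standing with compound 1, for which no number was reported either. Among the compounds with values here, the one step that has been measured around it is an at least 2.9-fold higher number from compound 2 to compound 3 (0.47 log units; beyond the scatter), so capping the amine with an amide-type group already moved the read-out to the weak side; this is the only evidence bearing on the next change. Compound 4, `COc1ccc(/C(=C(/CCNC(=O)C(=O)NC2CCCCC2)c2ccccc2)c2ccccc2)cc1`, differs from compound 3 in one place: cyclohexylcarbamoyl in place of diethylamino on a carbonyl carbon. Within the data shown here, since compound 3 sits at the limit of > 50000 nM in this assay, at which 1 of the 3 values shown sits, and the only measured step points toward weaker inhibition, a further amide-type change is expected to leave compound 4 near the weak end, with a step of about an at least 1.1-fold lower number from compound 3 to compound 4 (0.04 log units; that floor lies within the scatter) expected. Compound 4 is therefore estimated at 45000 nM, within a range of 15000 nM to 150000 nM.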

Compound 4, half-maximal inhibitory concentration: 12100 nM
Estimate against measurement, compound 4: 3.7-fold (0.57 log units) above; measured number outside the range, below it.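

Swapping diethylamino for cyclohexylcarbamoyl on the carbonyl carbon gives, in this assay, an at least 4.1-fold lower number from compound 3 to compound 4 (0.61 log units; beyond the scatter), so the group at this place does affect the read-out. Capping the amine nitrogen therefore need not weaken it: the diethylcarbamoyl cap gave an at least 2.9-fold higher number from compound 2 to compound 3 (0.47 log units; beyond the scatter), whereas the new cap gives a 1.4-fold lower number from compound 2 to compound 4 (0.15 log units; within the scatter), which leaves these two compounds indistinguishable here. The result for compound 3 is a limit and not a number, so the first step has only a floor: the limit of > 50000 nM in this assay, at which 1 of the 4 values shown sits.

The change replaces the diethylamino group with a six-membered ring and also adds a carbonyl, and the compounds shown do not separate these two parts. A (diethylcarbamoyl)carbonyl group on the amine nitrogen, or a cyclohexylcarbamoyl group placed directly on it, would show which part carries the step.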